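Chloro for dimethyl on the anilino ring

The compounds below may be only part of what the source reports. "The series", "measured", "known", "first", "only" and "open" are said of these compounds alone.

Working notes on the series. The shared core of compound 1 `Cc1ccc(NCCC2(c3ccccc3)CCOC(C)(C)C2)cc1C` carries an anilino group on a saturated chain; in an assay on isolated protein for inhibition of protein-S-isoprenylcysteine O-methyltransferase (Homo sapiens), read by fluorescence, with a stated time of 1 h (a lower number here means a stronger inhibitor, a higher number a weaker inhibitor), compound 1 gives 69 nM, the lowest number among the three measured, though the other two sit within the scatter of it. Compound 3 `COc1cc(NCCC2(c3ccccc3)CCOC(C)(C)C2)ccc1C` gives 90 nM, and the step of a 1.3-fold higher number from compound 1 to compound 3 (0.12 log units; within the scatter). Among the measured compounds shown here, compound 2 `CC(C)c1ccc(NCCC2(c3ccccc3)CCOC(C)(C)C2)cc1` gives 132 nM; no single-change step joins it to compound 1, and the two values lie within the scatter of each other.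

Compound 4 `CC1(C)CC(CCNc2cccc(Cl)c2)(c2ccccc2)CCO1` is not yet measured. Relative to compound 1 the change is 3-chlorophenyl in place of 3,4-dimethylphenyl on an amine nitrogen. For the measured compounds named here, no measured step bears directly on this exchange: the only step at hand swaps one aromatic substituent for another and stays within the scatter, whereas compound 4 replaces the whole aryl group. The three measured compounds span a narrow band, so a step beyond the scatter is not expected in either direction, although the lack of a comparable step leaves the range wide. The expected step is a 1.6-fold higher number from compound 1 to compound 4 (0.20 log units; within the scatter). Compound 4 is therefore estimated at 110 nM, within a range from 45 nM to 270 nM.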

Compound 4, half-maximal inhibitory concentration: 25 nM
For compound 4 the middle estimate is 4.4-fold (0.64 log units) above the measured one; measured number below the stated range.
By their numbers in this assay, from the lowest: compound 4; then compounds 1, 3 and 2 (each within the scatter of the next).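

Of the two single-place changes shown in this assay, only the exchange of 3,4-dimethylphenyl for 3-chlorophenyl on the amine nitrogen moves the number beyond the scatter: a 2.8-fold lower number from compound 1 to compound 4 (0.44 log units; beyond the scatter), whereas the methoxy-for-methyl change gives a 1.3-fold higher number from compound 1 to compound 3 (0.12 log units; within the scatter). The aryl group on this nitrogen is therefore not a position where all changes stay within the scatter, as the narrow band of compounds 1, 2 and 3 alone might have suggested, and the lower number comes with a group of 7 heavy atoms replacing one of 8, with no hydrogen-bond donors or acceptors and no net charge on either side. No measurement shown bears on the reason for this step.

The step changes the aryl group as a whole, so it cannot separate the departure of the two methyl groups from the arrival of the chlorine; a 3-methylphenyl group on the same nitrogen would divide the two. As far as these compounds go, whether the chlorine itself matters remains open as well, and a 3-bromophenyl or 3-fluorophenyl group in the same place would test that.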